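The source may hold more compounds than are shown below. What is called first, only, known or untested is meant among the compounds shown, and "the series" means these compounds.

Compound 1 `Ic1ccccc1-c1ncco1`: 2.3
Compound 2 `FC(F)(F)c1ccccc1-c1ncco1`: 2.15
Compound 3 `FC(F)(F)c1ccccc1C1=NC(c2ccccc2)CO1`: 3.71

These three compounds have been measured in a physicochemical assay for lipophilicity; a higher number here means a more lipophilic compound, a lower number a more polar compound. Compound 1 and compound 2 differ in a single place: iodo in place of trifluoromethyl on an aromatic carbon. That exchange produced a number 0.15 log units higher from compound 2 to compound 1 (within the scatter), so the two values cannot be told apart here. Compound 3 stands beyond the scatter above both of the others. Compound 3 and compound 2 differ in more than one place, and the difference between the two cores is not broken down here.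

Compound 4 `Ic1ccccc1C1=NC(c2ccccc2)CO1` has not yet been measured in this assay. It differs from compound 3 by iodo in place of trifluoromethyl on an aromatic carbon. Among the compounds with values here, this is the same kind of change as the one between compound 2 and compound 1, though the surroundings are not identical: in compound 2 the changed carbon is ortho to a 1,3-oxazol-2-yl group (5 heavy atoms), whereas in compound 3 it is ortho to a large group. Within the data shown here, the only measured example of this exchange gave a number 0.15 log units higher from compound 2 to compound 1 (within the scatter), a step inside the scatter. Among the measured compounds shown here, because the one observed step of a number 0.15 log units higher from compound 2 to compound 1 (within the scatter) was so small, compound 4 is expected to show a number 0.15 log units higher from compound 3 to compound 4 (within the scatter), keeping it close to compound 3. For compound 4 the estimate in this assay is 3.86, expected to fall between 3.4 and 4.3.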

Compound 4, partition coefficient: 3.86
For compound 4 middle estimate and measured number coincide at the digits printed; low and high end bracket the measured number.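

In this assay, putting iodo in place of trifluoromethyl gave a number 0.15 log units higher from compound 3 to compound 4 (within the scatter) on one core and a number 0.15 log units higher from compound 2 to compound 1 (within the scatter) on the other, so the two compounds of each pair cannot be told apart. This shows that the exchange gave the same kind of result on both cores, a step inside the scatter each time, but two pairs are a small sample, and steps this small cannot show whether the two groups match exactly or whether a small real difference lies hidden. Nothing measured here explains the result on either core, so it stands as an observation only.

Among the compounds shown, only iodo and trifluoromethyl occupy this place on the aromatic ring, so it remains open whether an amine, a carboxylic acid or a longer chain there would give a similar step on both cores. From the compounds shown here alone, it also remains open whether the iodo and trifluoromethyl exchange would stay inside the scatter on a core other than these two, or on a different carbon of the aromatic ring.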